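The source may hold more compounds than are shown below. What is called first, only, known or untested is meant among the compounds shown, and "the series" means these compounds.

Measured compounds:
compound 1, `CCc1ccc(C(=O)/C=C/c2ccc3c(c2)B(O)OC3)cc1`, in an ADME assay on L929 cells (Mus musculus) for cytotoxicity, read by resazurin assay, with a stated time of 72 h; a lower number here means a stronger inhibitor, a higher number a weaker inhibitor: > 10 ug/mL
compound 2, `O=C(/C=C/c1ccc2c(c1)B(O)OC2)c1cccc(F)c1`, in this assay: > 10 ug/mL

Compound 1 is `CCc1ccc(C(=O)/C=C/c2ccc3c(c2)B(O)OC3)cc1`. In this assay compound 1 reaches only the limit of the measurement, > 10 ug/mL, and no number is known for it. Compound 2, `O=C(/C=C/c1ccc2c(c1)B(O)OC2)c1cccc(F)c1`, sits at the same limit in this assay, > 10 ug/mL, which again is a limit and not a number. Both values shown so far therefore stand at the limit of > 10 ug/mL in this assay, at which 2 of the 2 values shown sit, and nothing within these two compounds separates one from the other.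

Compound 3 is `CCOC(=O)c1ccc(C(=O)/C=C/c2ccc3c(c2)B(O)OC3)cc1`. It differs from compound 1 in one place: ethoxycarbonyl in place of ethyl on an aromatic carbon. For the measured compounds named here, no step between measured compounds is available to judge what such a change does in this assay. Given that compound 1 and compound 2 both sit at the limit, the step that the limit leaves unreadable from compound 1 to compound 3 is expected to be small and most likely to stay within the scatter, with compound 3 again most probably reported only as a limit. Compound 3 is thus estimated at 15 ug/mL, with a range from 7 ug/mL to 40 ug/mL.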

Compound 3, half-maximal inhibitory concentration: > 10 ug/mL
Compound 3 was reported as a limit; the forecaster's own chance of this, stated with the estimate: 70%; the middle value lies beyond the limit too.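

Compound 3, like compound 1, is reported in this assay only as a limit, so no step can be read from compound 1 to compound 3, and swapping ethyl for ethoxycarbonyl shows no measurable consequence here. The compounds shown leave open how strongly any of them acts in this assay, since every value stands at one limit: the limit of > 10 ug/mL in this assay, at which 3 of the 3 values shown sit.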